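Replacing the side chain of compound 1 with an amine-bearing chain

A few compounds are considered here, and "the series" means these few. Any claim that something is new, unique, unknown or untested is made for them only; others in the source may bear on it.

Compound 1, `CC[C@H](C)[C@H](NC(=O)CN(c1nc(Cl)nc2[nH]cnc12)C1CC1)C(=O)O`, gives 27.4% in a functional assay on the whole organism (Tail, strain ICR) with Mus musculus as the target, in the tail flick test, with a stated time of 90 min, at a dose of 25 umol/kg by the oral route; a higher number here means a stronger effect of the compound at the dose given, a lower number a weaker effect. Compound 2, `CC[C@H](C)[C@H](NC(=O)CN(c1ncnc2c1ncn2C1CCCCO1)C1CC1)C(=O)OCc1ccccc1`, gives 22.6%, and compound 3, `CC[C@H](C)[C@H](NC(=O)CN(c1nc(Cl)nc2[nH]cnc12)C1CC1)C(=O)OCc1ccccc1`, gives 36.3%; the gaps from compound 1 to both lie within the usual scatter, so the three numbers cannot be told apart. Among the measured compounds shown here, the only measured step, a number 8.9 percentage points higher from compound 1 to compound 3 (within the scatter), concerns the oxygen next to a carbonyl group and not the side chain. Compound 4, `NCCCC[C@H](NC(=O)CN(c1nc(Cl)nc2[nH]cnc12)C1CC1)C(=O)O`, differs from compound 1 by 4-aminobutyl in place of sec-butyl on a saturated chain carbon bound to an amide-type nitrogen and a carbonyl carbon. For the measured compounds named here, no measured step touches this position, so no change beyond the scatter is expected, and the step from compound 1 to compound 4 is estimated as a number 0.4 percentage points lower from compound 1 to compound 4 (within the scatter). Compound 4 is therefore expected to give 27%, between 10% and 45%.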

Compound 4, a percentage reported as activity, at one dose (the size of the read-out at that dose, not a potency): 28.8%
Estimate against measurement, compound 4: 1.8 percentage points below; low and high end bracket the measured number.
By their numbers in this assay, from the lowest: compounds 2, 1, 4 and 3 (each within the scatter of the next, the first and the last beyond it).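

At this position, on a saturated chain carbon bound to an amide-type nitrogen and a carbonyl carbon, 4-aminobutyl in place of sec-butyl gives a number 1.4 percentage points higher from compound 1 to compound 4 (within the scatter). An amine-ended chain can therefore stand here without a change in this assay that can be told from the scatter. Nothing available explains this result.

The compounds shown leave open whether a shorter or longer amine-bearing chain, or a chain ending in a hydroxyl group or a guanidine, would behave the same way. They also leave open how 4-aminobutyl behaves alongside the benzyl ester.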